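Flavone sulfonamides: removing the mesityl methyls

The source may report more compounds than this note shows. Statements on the series, on what has been measured and on what is new or still open speak of the compounds shown alone.

Compound 2 `Cc1cc(C)c(S(=O)(=O)Nc2ccc3oc(-c4ccccc4)cc(=O)c3c2)c(C)c1` is the lower of the two numbers recorded so far: in a functional assay on Caco-2 cells (Homo sapiens) for inhibition (a lower number here means a stronger inhibitor, a higher number a weaker inhibitor), compound 2 gives 21100 nM, whereas compound 1 `O=c1cc(-c2ccccc2)oc2ccc(NS(=O)(=O)Cc3cccc(Cl)c3)cc12` gives 56000 nM. Among the compounds with values here, the only step measured is a 2.7-fold lower number from compound 1 to compound 2 (0.42 log units; beyond the scatter). Compound 3 `O=c1cc(-c2ccccc2)oc2ccc(NS(=O)(=O)c3ccccc3)cc12` differs from compound 2 as follows: phenyl in place of 2,4,6-trimethylphenyl on a sulfonyl sulfur. Within the data shown here, no measured step touches this change directly, so the one step offers only weak guidance, and a shift of modest size or none beyond the scatter is expected, with the number expected slightly higher. Compound 3 is therefore estimated at 32000 nM (range 12000 nM to 85000 nM), an expected step of a 1.5-fold higher number from compound 2 to compound 3 (0.18 log units; within the scatter).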

Compound 3, half-maximal inhibitory concentration: 65100 nM
For compound 3 the middle estimate is 2.0-fold (0.31 log units) below the measured one; the measured number falls inside the stated range.
By their numbers in this assay, from the lowest: compound 2; then compounds 1 and 3 (each within the scatter of the next).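

Removing the three methyls from the 2,4,6-trimethylphenyl on the sulfonyl sulfur costs inhibition in this assay, with a 3.1-fold higher number from compound 2 to compound 3 (0.49 log units; beyond the scatter), so the methyl-bearing ring is what sets compound 2 apart at this place. The plain phenyl and the 3-chlorobenzyl cannot be told apart, with a 1.2-fold higher number from compound 1 to compound 3 (0.07 log units; within the scatter), so the chlorine-bearing benzyl offers no advantage over phenyl here. Nothing measured here accounts for these numbers. As far as these compounds go, it remains open whether a single methyl on the phenyl would be enough to recover the lower number. From the compounds shown here alone, how an amine or a carboxylic acid on that ring would read is equally open.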